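Swapping the Methoxyphenyl for a Pyridinyl on the Carbonyl

The source may report more compounds than this note shows. Statements on the series, on what has been measured and on what is new or still open speak of the compounds shown alone.

Compound 2 `COc1ccccc1C(=O)C(CSC(=S)N(C)C)CSC(=S)N(C)C` and compound 1 `CC(=O)C(CSC(=S)N(C)C)CSC(=S)N(C)C` share one core and differ only in the group attached to the carbonyl carbon. In a functional assay on NCI-H460 cells (Homo sapiens) for inhibition, read by MTT assay, with a stated time of 72 h (on this read-out higher numbers stand for weaker inhibition and lower numbers for stronger inhibition), compound 1 gives 890 nM, and in this assay compound 2 gives 810 nM. Going by the values given here, the single measured step, a 1.1-fold lower number from compound 1 to compound 2 (0.04 log units; within the scatter), shows that replacing the methyl by a 2-methoxyphenyl at that carbonyl left the number essentially unchanged. Compound 2 therefore holds the lowest of the two numbers shown, but its nearest neighbour, compound 1, sits within the scatter, so neither can be called the more potent.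

Compound 3 `CN(C)C(=S)SCC(CSC(=S)N(C)C)C(=O)c1cccnc1` is not yet measured. It differs from compound 2 by pyridin-3-yl in place of 2-methoxyphenyl on a carbonyl carbon. Among the compounds with values here, the only step that bears on this position is the one from methyl to 2-methoxyphenyl, and it stayed within the scatter, so a change at the same carbonyl carbon is expected to give no step beyond the scatter: a 1.0-fold lower number from compound 2 to compound 3 (0.01 log units; within the scatter) is the expected outcome. Compound 3 is therefore estimated at 800 nM in this assay, with a range from 400 nM to 1600 nM.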

Compound 3, half-maximal inhibitory concentration: 870 nM
The estimate for compound 3 lay 1.1-fold (0.04 log units) below the measured number; the range from low to high includes it.
By their numbers in this assay, from the lowest: compounds 2, 3 and 1 (each within the scatter of the next).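

In this assay, pyridin-3-yl in place of 2-methoxyphenyl on the carbonyl carbon gives a 1.1-fold higher number from compound 2 to compound 3 (0.03 log units; within the scatter) and pyridin-3-yl in place of methyl gives a 1.0-fold lower number from compound 1 to compound 3 (0.01 log units; within the scatter) so all three compounds now sit within the scatter of one another. Until now, this carbonyl carbon had carried only a methyl and an aromatic ring of carbon only; the new result shows that an aromatic ring with a hetero atom, here with fewer heavy atoms than 2-methoxyphenyl, also leaves the number in the same place. Across these three groups, the read-out does not separate small from large or carbon-only from nitrogen-containing, and no supporting measurement is available to explain this flat result.

From the compounds shown here alone, whether any group at this carbon can move the number beyond the scatter remains open, for example a carboxylic acid, an aminomethyl group or a longer chain such as n-butyl. All three compounds also share the rest of the core unchanged, so what a change elsewhere would do cannot be told from them.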